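A Sulfonylated Pyrrolidine Replaces a Piperidine on the Core

The compounds below may be only part of what the source reports. "The series", "measured", "known", "first", "only" and "open" are said of these compounds alone.

Compound 1 `CN1CCN(c2ccc(Nc3ncc4nc(Nc5ccc(F)cc5)n([C@H]5CCCNC5)c4n3)cc2)CC1`: "not determined" (no result reported)
Compound 2 `CN1CCN(c2ccc(Nc3ncc4nc(Nc5ccc(F)cc5)n(-c5cccc(NC(=O)CO)c5)c4n3)cc2)CC1`: 1670 nM
Compound 3 `CN1CCN(c2ccc(Nc3ncc4nc(Nc5ccc(F)cc5)n([C@@H]5CCNC5)c4n3)cc2)CC1`: "not determined" (no result reported)

Three compounds in this set share a common core and were examined in a functional assay on A-431 cells (Homo sapiens) for antiproliferative activity, read by MTT assay, with a stated time of 72 h; a lower number here means a stronger inhibitor, a higher number a weaker inhibitor. Only compound 2 returned a number: in this assay compound 2 gives 1670 nM. For compound 1 the entry in this assay reads "not determined" (no result reported), and for compound 3 the entry in this assay reads "not determined" (no result reported), so compound 1 stands nowhere on the numbers shown and no step between measured compounds can be drawn.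

Compound 4 `CN1CCN(c2ccc(Nc3ncc4nc(Nc5ccc(F)cc5)n([C@H]5CCN(S(=O)(=O)C6CC6)C5)c4n3)cc2)CC1` is the next member to be tested. It differs from compound 1 in one place: 1-(cyclopropylsulfonyl)pyrrolidin-3-yl in place of piperidin-3-yl on an aromatic nitrogen. Among the measured compounds shown here, since compound 1 carries no number, the size of the step in this assay from compound 1 to compound 4 cannot be read from the data, and any direction given here is an expectation only, resting on the single value of compound 2.

On that basis compound 4 is expected to give about 500 nM in this assay, with a range from 100 nM to 3000 nM.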

Compound 4, half-maximal inhibitory concentration: 1670 nM
Compound 4: middle estimate off by 3.3-fold (0.52 log units), on the low side, and the stated range covers the measured number.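

At the aromatic nitrogen, this assay now allows a first comparison: replacing the 3-(((hydroxymethyl)carbonyl)amino)phenyl group with 1-(cyclopropylsulfonyl)pyrrolidin-3-yl gives no change at the digits printed from compound 2 to compound 4 (within the scatter). For this pair, therefore, a non-aromatic five-membered ring bearing a cyclopropylsulfonyl group and an aromatic ring bearing a hydroxyacetyl amide read alike, although this single pair establishes no general pattern for the position. No measurement shown offers an explanation for this match.

Compound 1 and compound 3 still have no number, so the steps linking them to compound 4 cannot be read, and the separate contributions of the ring size and the sulfonyl group remain unresolved. Also open, from the compounds shown here alone, is how a methylsulfonyl or acetyl group on the pyrrolidine nitrogen, or a cyclopropylsulfonyl group on a piperidin-3-yl ring, would read in this assay.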